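A few compounds are considered here, and "the series" means these few. Any claim that something is new, unique, unknown or untested is made for them only; others in the source may bear on it.

Working notes on the series. Compound 3 `CN(C)CCn1cnnc1-c1cc(Oc2ccc(NC(=O)N/N=C/c3ccccc3)cc2F)ccn1` has no single number in an ADME assay on WI-38 cells (Homo sapiens) for cytotoxicity, read by MTT assay, with a stated time of 72 h; on this read-out higher numbers stand for weaker inhibition and lower numbers for stronger inhibition; its result is given as "not determined" (no result reported). Compound 4 `CN(C)CCn1cnnc1-c1cc(Oc2ccc(NC(=O)N/N=C/c3cccc(Cl)c3Cl)cc2F)ccn1` differs from it by 2,3-dichlorophenyl in place of phenyl on a carbon with a double bond to nitrogen. For the measured compounds named here, no measured step covers this change. Compound 1 `CN(C)CCn1cnnc1-c1cc(Oc2ccc(NC(=O)N/N=C/c3c[nH]c4ccccc34)cc2F)ccn1` in this assay gives 3620 nM, and compound 2 `CN(C)CCn1cnnc1-c1cc(Oc2ccc(NC(=O)N/N=C/c3ccc(O)c(Br)c3)cc2F)ccn1` gives 5560 nM. Going by the values given here, the one measured step, a 1.5-fold higher number from compound 1 to compound 2 (0.19 log units; within the scatter), concerns a different exchange of aromatic groups on the same carbon and stayed within the scatter. Among the compounds with values here, with compound 3 unmeasured, no step to compound 4 can be computed, so the expectation rests only on the two measured compounds lying close together. Compound 4 is therefore expected near them, estimated at 4500 nM with a range of 1800 nM to 12000 nM.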

Compound 4, half-maximal inhibitory concentration: 6130 nM
Compound 4: middle estimate off by 1.4-fold (0.13 log units), on the low side; measured number inside the range.
By their numbers in this assay, from the lowest: compounds 1, 2 and 4 (each within the scatter of the next).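

In this assay, the exchange on the carbon with a double bond to nitrogen gives a 1.1-fold higher number from compound 2 to compound 4 (0.04 log units; within the scatter) and a 1.7-fold higher number from compound 1 to compound 4 (0.23 log units; within the scatter). All three aromatic groups shown here, including 2,3-dichlorophenyl, therefore give numbers within the scatter of one another, a result that previously rested on a single step. Nothing available explains this result.

The step from compound 3 to compound 4 cannot be read, so the contribution of the two chlorine atoms stays unresolved. Going by these compounds, whether a group such as an amine or a carboxylic acid in this place would give a number beyond the scatter remains open.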